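The compounds below may be only part of what the source reports. "The series", "measured", "known", "first", "only" and "open" are said of these compounds alone.

Measured in an assay on isolated protein for inhibition of Maltase-glucoamylase (Homo sapiens), with stated times of 15 min and 10 min, tested at 64 uM; a higher number here means more inhibition at the concentration tested (going by the name of the read-out), a lower number less inhibition:
- compound 1 `C=CCc1cc(-c2ccc(O)c(CC=C)c2)c(O)c(C(c2ccc(OC)cc2)N2CCCCC2)c1` gives 85%
- compound 2 `C=CCc1cc(-c2ccc(O)c(CC=C)c2)c(O)c(C(c2ccccc2)N2CCCCC2)c1` gives 13.6%
- compound 3 `C=CCc1cc(-c2ccc(O)c(CC=C)c2)c(O)c(C(c2ccccc2)N2CCC(C)CC2)c1` gives 25.8%

Compound 3 stands second of the three in this assay, beyond the scatter above compound 2 and well below compound 1. Compound 4 `C=CCc1cc(-c2ccc(O)c(CC=C)c2)c(O)c(C(c2cc(Cl)cc(Cl)c2)N2CCC(C)CC2)c1` is not yet measured; it differs from compound 3 by 3,5-dichlorophenyl in place of phenyl on a saturated chain carbon bound to an amine nitrogen in a ring and an aromatic carbon. Among the compounds with values here, the only step touching the same aryl group is a number 71.4 percentage points lower from compound 1 to compound 2 (beyond the scatter), a large one, so the substitution pattern of this ring matters strongly here; the other step, a number 12.2 percentage points higher from compound 2 to compound 3 (beyond the scatter), sits elsewhere and was modest. Within the data shown here, no chloro-bearing analogue exists in the set, so the direction is uncertain, but a step beyond the scatter is expected, a number 14.2 percentage points higher from compound 3 to compound 4 (beyond the scatter). For compound 4 the estimate in this assay is 40%, ranging from 10% to 75%.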

Compound 4, a percentage reported as inhibition, at one concentration (the size of the read-out at that concentration, not a potency): 97.5%
Beside the measured number, compound 4's estimate is 57.5 percentage points below it, outside the stated range (above it).
By their numbers in this assay, from the lowest: compound 2; then compound 3; then compound 1; then compound 4.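

In this assay, the aryl group on the saturated chain carbon bound to an amine nitrogen in a ring can carry a large gain as well as a large loss: 3,5-dichlorophenyl in place of phenyl gives a number 71.7 percentage points higher from compound 3 to compound 4 (beyond the scatter). The entering group has 0 hydrogen-bond acceptors, so a high read-out at this position does not require one on the aryl group. No measurement available here accounts for the size of this step.

Open, on these data alone, is whether 3,5-difluorophenyl or 3,5-dimethylphenyl would behave like 3,5-dichlorophenyl. Also open, as far as these compounds go, is whether 3,5-dichlorophenyl would give a similar read-out without the methyl on the saturated ring carbon.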